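A few compounds are considered here, and "the series" means these few. Any claim that something is new, unique, unknown or untested is made for them only; others in the source may bear on it.

Compound 1 `Cc1ccc(C(=O)/C=C/c2cc(O)nc(O)n2)cc1`: 1800 nM
Compound 2 `COc1ccc(C(=O)/C=C/c2cc(O)nc(O)n2)cc1`: 2200 nM

Within the data shown here, in a functional assay on CCRF-CEM cells (Homo sapiens) for cytotoxicity (on this read-out lower numbers stand for stronger inhibition and higher numbers for weaker inhibition), compound 1 gives 1800 nM, and compound 2, the only other measured compound, gives 2200 nM. Among the measured compounds shown here, the two cannot be told apart, so compound 1 stands level with its single neighbour on these numbers.

Compound 3 `Cc1ccc(C(=O)/C=C/c2nc(O)nc(O)c2Cl)cc1` keeps the methyl group of compound 1 and differs from it by chloro in place of hydrogen on an aromatic carbon. In words, this is chloro in place of hydrogen on an aromatic carbon, on the six-membered aromatic ring with 2 nitrogen. For the measured compounds named here, only one measured step offers any guidance, a 1.2-fold higher number from compound 1 to compound 2 (0.09 log units; within the scatter), and it is small. However, it replaces methyl with methoxy and leaves the carbon that changes in compound 3 untouched, so it bears only indirectly on this change. Going by the values given here, no measured compound carries a chloro group. With so little evidence, no step beyond the scatter is expected in this assay, and the uncertainty stays wide in both directions. The estimated step is a 1.2-fold lower number from compound 1 to compound 3 (0.08 log units; within the scatter). Compound 3 is expected at about 1500 nM, with an estimated range from 500 nM to 5000 nM.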

Compound 3, half-maximal inhibitory concentration: 12200 nM
Beside the measured number, compound 3's estimate is 8.1-fold (0.91 log units) below it; the measured number lies above the stated range.
By their numbers in this assay, from the lowest: compounds 1 and 2 (each within the scatter of the next); then compound 3.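

In this assay, among these compounds, the aromatic carbon that carries hydrogen in compound 1 proves sensitive to substitution: chloro in place of hydrogen there gives a 6.8-fold higher number from compound 1 to compound 3 (0.83 log units; beyond the scatter), the only step so far that lies beyond the scatter and a modest one. The earlier change, methoxy in place of methyl, gave a 1.2-fold higher number from compound 1 to compound 2 (0.09 log units; within the scatter) and left the two compounds indistinguishable, so a single change on the six-membered aromatic ring with 2 nitrogen has now moved the number in the direction of weaker inhibition, where the change at the methyl group did not. Nothing available here accounts for this weaker inhibition with chloro on this carbon.

The compounds shown leave open whether the result belongs to chloro alone or to any group on this carbon, since a fluoro, methyl or amino group in the same place could behave differently. They also leave open whether chloro would give a step of similar size on the core of compound 2, which carries methoxy instead of methyl.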